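Amide-to-sulfonamide switch on the shared core

The source may hold more compounds than are shown below. What is called first, only, known or untested is meant among the compounds shown, and "the series" means these compounds.

Among the measured compounds shown here, compound 2 `COc1cccc(C(=O)N(C)c2ccc3[nH]c(-c4n[nH]c5ccccc45)cc3n2)c1` holds the lowest of the two numbers so far: in a functional assay on HL-60 cells (Homo sapiens) for antiproliferative activity, read by MTT assay, with a stated time of 72 h (on this read-out higher numbers stand for weaker inhibition and lower numbers for stronger inhibition), compound 2 gives 1420 nM. Its nearest neighbour, compound 1 `CCC(=O)N(C)c1ccc2[nH]c(-c3n[nH]c4ccccc34)cc2n1`, gives 6130 nM in this assay, and the step of a 4.3-fold lower number from compound 1 to compound 2 (0.64 log units; beyond the scatter) lies beyond the scatter. Compound 3 `Cc1ccc(S(=O)(=O)N(C)c2ccc3[nH]c(-c4n[nH]c5ccccc45)cc3n2)cc1` is not yet measured; it differs from compound 2 by (4-methylphenyl)sulfonyl in place of (3-methoxyphenyl)carbonyl on a nitrogen on an aromatic ring. For the measured compounds named here, the only measured step bears on this change indirectly: a 4.3-fold lower number from compound 1 to compound 2 (0.64 log units; beyond the scatter) came with an aryl group on the carbonyl carbon in place of ethyl. Going by the values given here, compound 3 keeps an aryl group but exchanges the carbonyl for a sulfonyl and the methoxy for a methyl, a change for which no measured pair exists. The expected step of a 1.5-fold higher number from compound 2 to compound 3 (0.19 log units; within the scatter) is therefore small, likely within the scatter, with a lean toward a somewhat higher number. For compound 3 the estimate in this assay is 2200 nM, ranging from 600 nM to 8000 nM.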

Compound 3, half-maximal inhibitory concentration: 3030 nM
Estimate against measurement, compound 3: 1.4-fold (0.14 log units) below, and the stated range covers the measured number.
By their numbers in this assay, from the lowest: compound 2; then compound 3; then compound 1.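

In this assay, the nitrogen on the aromatic ring also accepts a sulfonyl link, with a 2.0-fold lower number from compound 1 to compound 3 (0.31 log units; beyond the scatter) showing that (4-methylphenyl)sulfonyl still gives a lower number than propanoyl. Against the aryl amide, however, the exchange goes the other way, with a 2.1-fold higher number from compound 2 to compound 3 (0.33 log units; beyond the scatter), so among these three compounds the (3-methoxyphenyl)carbonyl group remains the one with the lowest number. No measurement on hand accounts for either step.

The compounds shown leave open whether the step from the amide to the sulfonamide follows from the link or from the ring substituent, a question that (3-methoxyphenyl)sulfonyl and (4-methylphenyl)carbonyl would separate. Also open, going by these compounds, is how this position responds to an aryl group carrying an amine or a carboxylic acid.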